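Swapping 3-Fluorophenyl for 4-Fluorophenyl

The source may hold more compounds than are shown below. What is called first, only, known or untested is meant among the compounds shown, and "the series" means these compounds.

Among the compounds with values here, in a physicochemical assay for lipophilicity, at pH 7.4 (on this read-out higher numbers stand for higher lipophilicity and lower numbers for lower lipophilicity), compound 1 `CNC(=O)c1cc(C(=O)NC2CC2)cc2c1OC[C@H]2c1cccc(F)c1` gives 3.7 and holds the lower of the two numbers so far. Compound 2 `CNC(=O)c1cc(C(=O)N[C@H]2C[C@@H]2C)cc2c1OC[C@@]2(C)c1ccccc1` gives 4.7 which lies higher by a gap beyond the usual scatter. Compound 3 `CNC(=O)c1cc(C(=O)NC2CC2)cc2c1OC[C@H]2c1ccc(F)cc1` carries 4-fluorophenyl in place of 3-fluorophenyl on a saturated ring carbon and still awaits measurement. Within the data shown here, no measured pair shows such a swap, so the expected step of no change at the digits printed from compound 1 to compound 3 (within the scatter) in this assay is none beyond the scatter, with neither direction favoured. For compound 3 the estimated value is 3.7 with an expected range from 3.3 to 4.1 on this scale.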

Compound 3, distribution coefficient: 3.8
Compound 3: middle estimate off by 0.10 log units, on the low side; low and high end bracket the measured number.
By their numbers in this assay, from the lowest: compounds 1 and 3 (each within the scatter of the next); then compound 2.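

In this assay, within the data shown here, putting 4-fluorophenyl in place of 3-fluorophenyl on this saturated ring carbon gives a number 0.10 log units higher from compound 1 to compound 3 (within the scatter) and is the first single-place comparison in this set. On this read-out, the two fluorophenyl groups cannot be told apart at this position. No supporting measurement bears on why this is so.

Compound 2 differs from compound 1 and compound 3 in more than one place, so its number cannot be tied to any single change. From the compounds shown here alone, how an amine or a carboxylic acid on this phenyl ring would read remains open.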